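A few compounds are considered here, and "the series" means these few. Any claim that something is new, unique, unknown or untested is made for them only; others in the source may bear on it.

Compounds with measured values:
compound 1, `COc1ccc(Nc2nccc(-c3sc(SC(C)C)nc3C)n2)c(OC)c1`, 1300 nM in an assay for inhibition of MAP kinase-interacting serine/threonine-protein kinase 2 (Homo sapiens), read by TR-FRET; on this read-out higher numbers stand for weaker inhibition and lower numbers for stronger inhibition;
compound 2, `COCCSc1nc(C)c(-c2ccnc(Nc3ccc(OC)cc3OC)n2)s1`, 1700 nM in this assay;
compound 3, `CNc1nc(C)c(-c2ccnc(Nc3ccc(OC)cc3OC)n2)s1`, 110 nM in this assay.

Compound 3 stands lowest of the three numbers. Its nearest neighbour is compound 1, separated by a 12-fold lower number from compound 1 to compound 3 (1.07 log units; beyond the scatter), and the other gap is a 15-fold lower number from compound 2 to compound 3 (1.19 log units; beyond the scatter); both gaps lie beyond the scatter, so compound 3 is the strongest inhibitor of the three. The two thioether compounds, compound 1 and compound 2, differ from each other by only a 1.3-fold higher number from compound 1 to compound 2 (0.12 log units; within the scatter), a step within the scatter.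

Compound 4, `COc1ccc(Nc2nccc(-c3sc(N(C)C)nc3C)n2)c(OC)c1`, is not yet measured. It differs from compound 3 by methyl in place of hydrogen on a nitrogen on an aromatic ring.

Among the compounds with values here, none of the measured steps bears directly on this change. The large steps from compound 1 and compound 2 to compound 3 concern the exchange of an isopropylsulfanyl or (2-methoxyethyl)sulfanyl group for methylamino, not the addition of a methyl to the methylamino nitrogen. Within the data shown here, the small step between compound 1 and compound 2 shows only that varying the group on the sulfur hardly matters. Among the measured compounds shown here, with no step of the same kind available, compound 4 is expected to stay near compound 3, with a step of a 1.5-fold higher number from compound 3 to compound 4 (0.16 log units; within the scatter) in this assay that may fall within the scatter. Compound 4 is therefore estimated at 160 nM in this assay, with a range from 50 nM to 550 nM.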

Compound 4, inhibition constant: 200 nM
Compound 4: the middle estimate sits 1.3-fold (0.10 log units) below what was measured; the range from low to high includes it.
By their numbers in this assay, from the lowest: compounds 3 and 4 (each within the scatter of the next); then compounds 1 and 2 (each within the scatter of the next).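

In this assay, the nitrogen on the aromatic ring accepts methyl in place of its remaining hydrogen with no change beyond the scatter (a 1.8-fold higher number from compound 3 to compound 4 (0.26 log units; within the scatter)), so methylamino and dimethylamino cannot be told apart here. The advantage of an amino group over the thioethers therefore does not rest on that hydrogen, since dimethylamino, which has none on this nitrogen, still stands clearly apart from both thioether compounds (an 8.5-fold lower number from compound 2 to compound 4 (0.93 log units; beyond the scatter); a 6.5-fold lower number from compound 1 to compound 4 (0.81 log units; beyond the scatter)), though these two steps are modest rather than large. No measurement in hand accounts for this separation between the amino and thioether groups.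

The compounds shown leave open how the unsubstituted amine would read in this assay, and whether a longer chain on this nitrogen, such as ethyl or 2-methoxyethyl, would stay with compound 3 and compound 4 or move toward the thioethers. They also leave open whether a ring amine such as pyrrolidine or morpholine at this position would keep the same level of inhibition.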